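Cyano in Place of Bromo on Two Cores

This account rests on a few compounds, and the source may have more. Where it says the series, first, only, none or still open, it means among the compounds named here.

Compounds 1 and 2 share one core: compound 1 `Cc1cc(C#N)cc(C)c1Oc1ccnc(Nc2ccc(C#N)cc2)n1` carries a cyano where compound 2 `Cc1cc(Br)cc(C)c1Oc1ccnc(Nc2ccc(C#N)cc2)n1` carries a bromo. In a physicochemical assay for lipophilicity (on this read-out lower numbers stand for lower lipophilicity and higher numbers for higher lipophilicity), compound 2 gives 1.72, and compound 1 gives 1.39. The change cyano in place of bromo on an aromatic carbon made a step of a number 0.33 log units lower from compound 2 to compound 1 (beyond the scatter). Compound 3 `Cc1cc(C#N)cc(C)c1Nc1nc(Nc2ccc(C#N)cc2)ncc1Br` is built on a different core; the difference between the two cores is not broken down here. In this assay compound 3 gives 1.39, level with compound 1. Compound 4 `Cc1cc(C#N)cc(C)c1Nc1nc(Nc2ccc(C#N)cc2)ncc1C#N` is not yet measured and differs from compound 3 by cyano in place of bromo on an aromatic carbon. This is the same kind of change, but here the carbon lies in a six-membered aromatic ring with 2 nitrogen, ortho to a large group, two atoms from the ring nitrogen and para to a (4-cyanophenyl)amino group, rather than in a ring of carbon only, meta to two methyl groups and para to a large group. A step of a number 0.33 log units lower from compound 3 to compound 4 (beyond the scatter) is expected, resting on a number 0.33 log units lower from compound 2 to compound 1 (beyond the scatter). Compound 4 is therefore estimated at 1.06, between 0.75 and 1.4.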

Compound 4, partition coefficient: 1.06
The estimate for compound 4 equals the measured number at the digits printed; the measured number falls inside the stated range.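

In this assay cyano in place of bromo on an aromatic carbon gave a number 0.33 log units lower from compound 3 to compound 4 (beyond the scatter) and so matched in size a number 0.33 log units lower from compound 2 to compound 1 (beyond the scatter) on the other core. This shows that the change carried over in these two pairs, one on a ring of carbon only and one on a six-membered aromatic ring with 2 nitrogen, but two pairs do not show that it would hold on further cores or at other places. Nothing measured here explains why the two steps agree.

The compounds shown leave open how an amine or a carboxylic acid in place of the bromo would read on either core. They also leave open whether the same step would appear on a third core.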